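From 3-ethynylphenyl to 4-bromophenyl on compound 2

This account rests on a few compounds, and the source may have more. Where it says the series, first, only, none or still open, it means among the compounds named here.

Compound 1 `CN1CCN(c2ccc(Nc3ncc4nc(Nc5ccccc5)n(-c5ccccc5)c4n3)cc2)CC1` and compound 2 `C#Cc1cccc(Nc2nc3cnc(Nc4ccc(N5CCN(C)CC5)cc4)nc3n2C2CCCC2)c1` have been measured so far. In a functional assay on NCI-H1975 cells (Homo sapiens) for cytotoxicity, read by MTT assay, with a stated time of 72 h (on this read-out higher numbers stand for weaker inhibition and lower numbers for stronger inhibition), compound 1 gives 1830 nM and compound 2 gives 650 nM as the lower of the two numbers, a gap beyond the scatter. Compound 3 `CN1CCN(c2ccc(Nc3ncc4nc(Nc5ccc(Br)cc5)n(C5CCCC5)c4n3)cc2)CC1` carries 4-bromophenyl in place of 3-ethynylphenyl on a nitrogen on an aromatic ring and has not yet been measured. Going by the values given here, no measured step covers this change, so the estimated 1.4-fold higher number from compound 2 to compound 3 (0.14 log units; within the scatter) is expected to be modest, toward weaker inhibition in this assay and hardly beyond the scatter. Compound 3 is expected at 900 nM (estimated range 300 nM to 2700 nM).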

Compound 3, half-maximal inhibitory concentration: 2090 nM
Estimate against measurement, compound 3: 2.3-fold (0.37 log units) below; the measured number falls inside the stated range.
By their numbers in this assay, from the lowest: compound 2; then compounds 1 and 3 (each within the scatter of the next).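

In this assay the exchange of 3-ethynylphenyl for 4-bromophenyl on this nitrogen gives a 3.2-fold higher number from compound 2 to compound 3 (0.51 log units; beyond the scatter) and so shows that the position responds to the group it carries. Both groups hold one six-membered aromatic ring of carbon only and no hydrogen-bond donors or acceptors, yet the step lies beyond the scatter. No measurement at hand accounts for this step.

Open, on these data alone, is whether the step follows the substituent or its place on the ring, which 3-bromophenyl or 4-ethynylphenyl would separate. As far as these compounds go, how a nitrile or an amine on this ring would read also remains open.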